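From Quinolin-3-yl to (Cyclohex-1-en-1-yl)methyl: an Expected Step

A few compounds are considered here, and "the series" means these few. Any claim that something is new, unique, unknown or untested is made for them only; others in the source may bear on it.

Compound 1 `CCOC(=O)c1cnc(-c2cnc3ccccc3c2)nc1NN1C(=O)C=C(C)C1=O` gives 6000 nM in a functional assay on Jurkat cells for inhibition of nuclear factor NF-kappa-B complex (Homo sapiens); a higher number here means a weaker inhibitor, a lower number a stronger inhibitor.
Compound 2 `CCOC(=O)c1cnc(-c2ccc(C)s2)nc1NN1C(=O)C=C(C)C1=O` gives 200 nM in this assay.
Compound 3 `CCOC(=O)c1cnc(C2CC2)nc1NN1C(=O)C=C(C)C1=O` gives 1000 nM in this assay.

Among these three, compound 1 has the highest number and is therefore the weakest inhibitor of the set; compound 3 stands nearest to it and compound 2 furthest away. All three share the same core and differ only in the group attached to one aromatic carbon of that core. Compound 4 `CCOC(=O)c1cnc(CC2=CCCCC2)nc1NN1C(=O)C=C(C)C1=O` carries yet another group at that same place: (cyclohex-1-en-1-yl)methyl in place of quinolin-3-yl on an aromatic carbon.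

Two measured steps start from compound 1 and change exactly this position: a 30-fold lower number from compound 1 to compound 2 (1.48 log units; beyond the scatter), a large step, and a 6.0-fold lower number from compound 1 to compound 3 (0.78 log units; beyond the scatter), a modest one. The entering group of compound 4 is, like cyclopropyl, a non-aromatic ring of carbon only, so the closer guide is the step to compound 3. The step from compound 1 to compound 4 is therefore expected to be modest and downward, a 5.0-fold lower number from compound 1 to compound 4 (0.70 log units; beyond the scatter). Compound 4 is estimated at 1200 nM, with a likely range from 400 nM to 4000 nM.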

Compound 4, half-maximal inhibitory concentration: 2000 nM
Beside the measured number, compound 4's estimate is 1.7-fold (0.22 log units) below it; measured number inside the range.
By their numbers in this assay, from the lowest: compound 2; then compounds 3 and 4 (each within the scatter of the next); then compound 1.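

Putting (cyclohex-1-en-1-yl)methyl in place of quinolin-3-yl gives a 3.0-fold lower number from compound 1 to compound 4 (0.48 log units; beyond the scatter) and shows that a second group without an aromatic ring also gives a lower number than compound 1 does. A six-membered ring with a double bond and cyclopropyl cannot be told apart here, with a 2.0-fold higher number from compound 3 to compound 4 (0.30 log units; within the scatter) separating them. Changing 5-methylthiophen-2-yl to the same group gives a 10-fold higher number from compound 2 to compound 4 (1.00 log units; beyond the scatter) and shows that an aromatic ring at this place sets no simple rule: compound 2 has one and the lowest number of the four, while compound 1 has aromatic rings and the highest.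

As far as these compounds go, how an amine, a carboxylic acid or a longer chain at this place would behave remains open. No measurement available here explains why these groups differ.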